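From bromo to methoxy in a growth assay

A few compounds are considered here, and "the series" means these few. Any claim that something is new, unique, unknown or untested is made for them only; others in the source may bear on it.

Values in a functional assay on NCI-H460 cells (Homo sapiens) for inhibition, read by sulforhodamine B assay, with a stated time of 48 h; on this read-out higher numbers stand for weaker inhibition of growth and lower numbers for stronger inhibition of growth:
Compound 1 `CCOC(=O)c1nn(-c2ccc(Cl)cc2)c(-c2ccc(OC)cc2)c1CNC(C)(C)C`: 27000 nM; > 523000 nM (2 entries)
Compound 2 `CC(C)(C)NCc1c(C(=O)O)nn(-c2ccc(Cl)cc2)c1-c1ccc(Cl)cc1`: > 599000 nM
Compound 3 `CC(C)(C)NCc1c(C(=O)O)nn(-c2ccc(Cl)cc2)c1-c1ccc(Br)cc1`: > 542000 nM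
Compound 4 `COc1ccc(-c2c(CNC(C)(C)C)c(C(=O)O)nn2-c2ccc(Cl)cc2)cc1`: not yet measured

Compound 3 gives only a limit, > 542000 nM, so no exact number fixes where it stands. Compound 2 also gives only a limit, > 599000 nM. Compound 1 has two entries, 27000 nM; > 523000 nM (2 entries), and the two lie far apart.

The move to compound 4 is methoxy in place of bromo on an aromatic carbon, giving a 4-methoxyphenyl group in place of 4-bromophenyl. The nearest measured change is a step that the two limits leave unreadable from compound 2 to compound 3, with bromo in place of chloro on an aromatic carbon, so it offers no size to carry over. Compound 1 carries the same 4-methoxyphenyl group but differs from compound 4 elsewhere, and its record, (the several entries of compound 1 in this assay, 27000 nM; > 523000 nM (2 entries)), gives no single reading. No step beyond the scatter can therefore be argued for in this assay, in either direction.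

Compound 4 is expected to read like compound 3, whose value is a limit, > 542000 nM. The estimated change is a step that the limit leaves unreadable from compound 3 to compound 4. For compound 4 the expected value is 590000 nM, with an estimated range from 150000 nM to 800000 nM.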

Compound 4, concentration for 50% growth inhibition: > 605000 nM
Compound 4 was reported as a limit; the forecaster's own chance of this, stated with the estimate: 85%; middle value at least 1.0-fold (0.01 log units) from the limit.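

In this assay compound 4 gives only a limit, > 605000 nM. Compound 2 and compound 3 also give only limits, so the steps from either of them to compound 4 cannot be read. The compounds shown leave open whether swapping chloro, bromo and methoxy at this place changes growth inhibition in this assay at all.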